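Adenosine benzylamine analogues against a leukaemia cell line

The compounds below may be only part of what the source reports. "The series", "measured", "known", "first", "only" and "open" are said of these compounds alone.

Compound 1 `Cc1ccc(CNc2ncnc3c2ncn3[C@@H]2O[C@H](CO)[C@@H](O)[C@H]2O)cc1`
Compound 2 `COc1cc(CNc2ncnc3c2ncn3[C@@H]2O[C@H](CO)[C@@H](O)[C@H]2O)cc(OC)c1`
Compound 3 `COc1cccc(CNc2ncnc3c2ncn3[C@@H]2O[C@H](CO)[C@@H](O)[C@H]2O)c1O`

Of the compounds shown here, two have been measured in a functional assay on CCRF-CEM cells (Homo sapiens) for antiproliferative activity, with a stated time of 72 h; a lower number here means a stronger inhibitor, a higher number a weaker inhibitor. Compound 1 gives only a limit of the assay, > 166000 nM. Compound 2 likewise gives only a limit, > 166000 nM. For the measured compounds named here, the one step between them, a step that the two limits leave unreadable from compound 1 to compound 2, therefore cannot be read. Compound 2 thus stands at the limit, as the limit of > 166000 nM in this assay, at which 2 of the 2 values shown sit, sets out. The third compound, compound 3, differs from compound 2 in one place: 2-hydroxy-3-methoxyphenyl in place of 3,5-dimethoxyphenyl on a saturated chain carbon bound to a nitrogen on an aromatic ring. Going by the values given here, no measured step bears on this change, because the only step measured, a step that the two limits leave unreadable from compound 1 to compound 2, is itself unreadable. Nothing in the data points to a readable step in this assay from compound 2 to compound 3, and the most likely outcome is that compound 3 again returns only a limit. Compound 3 is therefore expected at 166000 nM, within 40000 nM to 600000 nM, which would mean an expected step of a number no higher from compound 2 to compound 3 (the limit leaves the size open).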

Compound 3, half-maximal inhibitory concentration: 300 nM
Compound 3: the middle estimate sits 550-fold (2.74 log units) above what was measured; measured number outside the range, below it.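

In this assay, the change to 2-hydroxy-3-methoxyphenyl gives an at least 550-fold lower number from compound 2 to compound 3 (2.74 log units; beyond the scatter), and measured against 4-methylphenyl the same group gives an at least 550-fold lower number from compound 1 to compound 3 (2.74 log units; beyond the scatter). The group on a saturated chain carbon bound to a nitrogen on an aromatic ring can therefore decide whether the shared core gives a readable number at all, which the earlier pair could not show, since the step between those two limits cannot be read. The entering group has 1 hydrogen-bond donor and 3,5-dimethoxyphenyl has 0, and the readable value of compound 3 stands apart from the rest of the set: the limit of > 166000 nM in this assay, at which 2 of the 3 values shown sit.

The compounds shown do not separate the hydroxy group of compound 3 from its methoxy group, so which of them carries the step stays open. On these data alone, whether an amine or a carboxylic acid in place of that hydroxy group would keep the activity also stays open.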